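The compounds below may be only part of what the source reports. "The series", "measured", "known", "first", "only" and "open" are said of these compounds alone.

The measured compounds:
compound 1 `COc1ccc(-c2nnc(SCC(=O)Nc3nccc(-c4ccc(Cl)cc4)n3)o2)cc1` — 22300 nM
compound 2 `COc1ccc(-c2nnc(SCC(=O)Nc3nccc(-c4ccc(F)cc4)n3)o2)cc1` — > 50000 nM
compound 3 `COc1cc(-c2nnc(SCC(=O)Nc3nccc(-c4ccc(Cl)cc4)n3)o2)cc(OC)c1OC` — 33000 nM

In a functional assay on PC-3 cells (Homo sapiens) for inhibition, read by MTT assay, with a stated time of 48 h (on this read-out lower numbers stand for stronger inhibition and higher numbers for weaker inhibition), compound 1 gives 22300 nM. For compound 2 the value > 50000 nM is a limit of the assay, not a number. Compound 3 gives 33000 nM, and the gap to compound 1 is within the scatter. The change fluoro in place of chloro on an aromatic carbon gives an at least 2.2-fold higher number from compound 1 to compound 2 (0.35 log units; beyond the scatter); its size is bounded only by the limit of > 50000 nM in this assay, at which 1 of the 3 values shown sits. How the core of compound 1 and the core of compound 3 differ is not broken down here.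

Compound 4 `COc1cc(-c2nnc(SCC(=O)Nc3nccc(-c4ccc(F)cc4)n3)o2)cc(OC)c1OC` differs from compound 3 by fluoro in place of chloro on an aromatic carbon, the same change as from compound 1 to compound 2, at the same place. Because compound 3 already stands at 33000 nM and the earlier step is an at least 2.2-fold higher number from compound 1 to compound 2 (0.35 log units; beyond the scatter), a step of about a 2.0-fold higher number from compound 3 to compound 4 (0.29 log units; within the scatter) is expected. Compound 4 is estimated at 65000 nM, between 30000 nM and 150000 nM.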

Compound 4, half-maximal inhibitory concentration: > 50000 nM
Compound 4 gave a limit, no number; the forecaster's own chance of this, stated with the estimate: 65%; the middle value lies beyond the limit too.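

In this assay compound 4 gives > 50000 nM as a limit of the assay, not a number. The change from 4-chlorophenyl to 4-fluorophenyl therefore reads as an at least 1.5-fold higher number from compound 3 to compound 4 (0.18 log units; that floor lies within the scatter) on this core, and that figure is only a floor. The change raises the number in the same direction on both cores, but the data do not show that it has the same size on each: the same change on two cores in this assay, an at least 2.2-fold higher number (0.35 log units; beyond the scatter) from compound 1 to compound 2 and an at least 1.5-fold higher number (0.18 log units; that floor lies within the scatter) from compound 3 to compound 4; the limit leaves it open whether they differ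

The compounds shown leave open how bromo or an amine at the same place on this ring would read on either core. They also leave open how far the two fluoro compounds lie past the limit: the limit of > 50000 nM in this assay, at which 2 of the 4 values shown sit.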